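The source may report more compounds than this note shows. Statements on the series, on what has been measured and on what is new or still open speak of the compounds shown alone.

Compound 1 `O=C(Nc1cccc(NC(=O)c2ccc(Cl)c(Cl)c2)c1)c1cccc(Cl)c1` and compound 2 `O=C(Nc1cccc(NC(=O)c2cccc(Cl)c2)c1)c1ccc(F)cc1` share one core, and compound 3 `O=C(Nc1cccc(NC(=O)C2CCCCC2)c1)c1cccc(Cl)c1` has not yet been measured. In an in vitro functional assay on HEK293-A cells for antagonist activity at metabotropic glutamate receptor 5 (Rattus norvegicus), read by calcium flux (a higher number here means a weaker inhibitor, a lower number a stronger inhibitor), compound 1 gives > 30000 nM, which is a limit of the assay and not a number. In this assay compound 2 gives > 30000 nM, again a limit rather than a number. The step that the two limits leave unreadable from compound 1 to compound 2 cannot be read, since both ends rest at the same limit as the limit of > 30000 nM in this assay, at which 2 of the 2 values shown sit, records. Compound 2 therefore stands at the limit of this assay with no measured number of its own.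

Compound 3 differs from compound 2 by cyclohexyl in place of 4-fluorophenyl on a carbonyl carbon. For the measured compounds named here, no measured step involves a cyclohexyl on that carbonyl carbon, and the only measured step, from compound 1 to compound 2, is itself unreadable, so nothing on the measured side sets a size or a direction for this change in this assay. With compound 2 at the limit, the expected outcome for compound 3 is another value near or beyond that limit. Compound 3 is expected to give about 30000 nM in this assay, within 8000 nM to 100000 nM. That estimate implies an expected step of a number no higher from compound 2 to compound 3 (the limit leaves the size open) that is not beyond the scatter.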

Compound 3, half-maximal inhibitory concentration: > 30000 nM
Compound 3 was reported as a limit (the forecaster's own chance of this, stated with the estimate: 75%); the middle value sits exactly at the limit.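

For the compounds shown here, with compound 3 added, no step among compound 1, compound 2 and compound 3 can be read in this assay, since all three rest at one limit: the limit of > 30000 nM in this assay, at which 3 of the 3 values shown sit. The compounds shown leave open how large any of these changes on the carbonyl carbon is, and what on the shared core would give a measurable value in this assay.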